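The compounds below may be only part of what the source reports. "The series", "measured", "known", "first", "only" and "open" are said of these compounds alone.

Compound 1, `O=C1O[C@H]([C@@H](O)Cn2ccc(NC(=O)c3ccccc3)nc2=O)C(OCc2ccccc2)=C1OCc1ccccc1`: 62200 nM
Compound 2, `O=C1O/C(=C\Cn2c(=O)[nH]c(=O)[nH]c2=O)C(OCc2ccccc2)=C1OCc1ccccc1`: 44800 nM
Compound 3, `NC1(CCn2ccc(=O)[nH]c2=O)OC(=O)C(OCc2ccccc2)=C1OCc1ccccc1`: > 100000 nM

Three compounds built on a shared core were tested in a functional assay on HepG2 cells (Homo sapiens) for inhibition, read by MTT assay, with a stated time of 72 h; on this read-out higher numbers stand for weaker inhibition and lower numbers for stronger inhibition. Compound 1 gives 62200 nM and compound 2 gives 44800 nM, two numbers that lie within the usual scatter of each other, so neither can be called the more active. Compound 3 stands apart: its result, > 100000 nM, is a limit of the assay rather than a number. Among the compounds with values here, it is the one compound here sitting at the limit of > 100000 nM in this assay, at which 1 of the 3 values shown sits. No pair of these compounds differs in only one place, so no measured step shows what a single change does on this core.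

Compound 4, `NC1(CCn2cc(F)c(=O)[nH]c2=O)OC(=O)C(OCc2ccccc2)=C1OCc1ccccc1`, has not yet been measured. It differs from compound 3 by fluoro in place of hydrogen on an aromatic carbon. Within the data shown here, with no comparable step among the measured compounds, the size of this change cannot be read from the data. The expected step of an at least 1.4-fold lower number from compound 3 to compound 4 (0.15 log units; that floor lies within the scatter) is modest and may not reach beyond the scatter, and compound 4 may again give only a limit. Compound 4 is estimated at 70000 nM, within an expected range from 15000 nM to 200000 nM.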

Compound 4, half-maximal inhibitory concentration: 42800 nM
Compound 4: middle estimate off by 1.6-fold (0.21 log units), on the high side; low and high end bracket the measured number.
By their numbers in this assay, from the lowest: compounds 4, 2 and 1 (each within the scatter of the next). At a limit, above all of these: compound 3.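

In this assay, within the data shown here, fluoro in place of hydrogen on an aromatic carbon gives the first measured single change on the shared core, with an at least 2.3-fold lower number from compound 3 to compound 4 (0.36 log units; beyond the scatter) as its result. A single added fluorine atom at this place on the six-membered aromatic ring is thus enough to bring the read-out from a limit to a measurable number. The real size of the step may be larger than the figure printed, because compound 3 has only a limit and no exact value: the limit of > 100000 nM in this assay, at which 1 of the 4 values shown sits.

From the compounds shown here alone, whether chloro, a methyl group or an amine at this same carbon would act like fluoro remains open. So does whether fluoro would shift the read-out in the same way on the cores of compound 1 and compound 2.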